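The source may report more compounds than this note shows. Statements on the series, on what has been measured and on what is new or still open speak of the compounds shown alone.

Measured so far, in a functional assay, read by spectrophotometry, with a stated time of 20 min; on this read-out lower numbers stand for stronger inhibition and higher numbers for weaker inhibition:
- compound 1 `CC(=O)c1ccc(NC(=O)C(C(C)C)N(C(=O)c2ccccc2)S(=O)(=O)c2ccc(C)cc2)cc1`: 12000000 nM
- compound 2 `CC(=O)c1ccc(NC(=O)C(CC(C)C)N(C(=O)c2ccccc2)S(=O)(=O)c2ccccc2)cc1`: 3200000 nM

Both numbers are very high, so each compound is only a weak inhibitor. Compound 2 stands at the lowest of the two numbers; compound 1 sits at a higher number, and the gap between the two lies beyond the usual scatter of repeated measurements. Compound 1 and compound 2 differ in two places at once, so no single step can be read from that pair.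

Compound 3 `CC(=O)c1ccc(NC(=O)C(C(C)C)N(C(=O)c2ccccc2)S(=O)(=O)c2ccccc2)cc1` has not yet been measured. Compared with compound 2, the change is isopropyl in place of isobutyl on a saturated chain carbon bound to an amide-type nitrogen and a carbonyl carbon. The shared core and everything else stay the same. For the measured compounds named here, no measured pair shows this change alone, so nothing here tells how large its effect will be. Since compound 3 sits structurally between compound 1 and compound 2, the number for compound 3 is expected to fall between their values, most likely somewhat higher than that of compound 2, a step of about a 1.9-fold higher number from compound 2 to compound 3 (0.27 log units; within the scatter). Compound 3 is therefore estimated at 6000000 nM, with a likely range from 2500000 nM to 15000000 nM.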

Compound 3, half-maximal inhibitory concentration: 13000000 nM
Compound 3: middle estimate off by 2.2-fold (0.34 log units), on the low side; low and high end bracket the measured number.
By their numbers in this assay, from the lowest: compound 2; then compounds 1 and 3 (each within the scatter of the next).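

Within this assay, isopropyl in place of isobutyl on a saturated chain carbon bound to an amide-type nitrogen and a carbonyl carbon gives a 4.1-fold higher number from compound 2 to compound 3 (0.61 log units; beyond the scatter) and so weakens the inhibition by more than the usual scatter of repeated measurements, which shows that this position responds to a change in the chain. The other change that can now be read on its own, hydrogen in place of methyl on an aromatic carbon, gives a 1.1-fold higher number from compound 1 to compound 3 (0.03 log units; within the scatter) and stays within that scatter, so the compounds shown reveal no real effect of that methyl when isopropyl occupies the chain position. No available measurement offers a reason for either result.

Only isobutyl and isopropyl appear at the chain position, so two groups cannot show whether a longer chain such as hexyl, or a chain ending in an amine or a carboxylic acid, would lower the number further. The aromatic methyl is also seen only alongside isopropyl, which leaves open whether it would matter alongside isobutyl.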